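Pyrimidin-2-yl in place of pyridin-2-yl: an expected step

The source may hold more compounds than are shown below. What is called first, only, known or untested is meant among the compounds shown, and "the series" means these compounds.

Compound 1 `Cc1cccc2sc(NC(=O)CCN3CCN(C(C)(C)C)CC3)nc12`, compound 2 `Cc1cccc2sc(NC(=O)CCN3CCN(CCN(C)C)CC3)nc12` and compound 3 `Cc1cccc2sc(NC(=O)CCN3CCN(c4ccccn4)CC3)nc12` share one core and differ only in the group on the amine nitrogen in a ring. In an assay on HEK293 cells for antagonist activity at P2X purinoceptor 7 (Homo sapiens), read by fluorescence, with stated times of 30 min and 120 min (on this read-out lower numbers stand for stronger inhibition and higher numbers for weaker inhibition), compound 2 gives 2150 nM and compound 3 gives 1400 nM. For compound 1 the entry reads no result reported. Among the compounds with values here, compound 3 thus holds the lower of the two numbers, with compound 2 as its only neighbour, and the step of a 1.5-fold lower number from compound 2 to compound 3 (0.19 log units; within the scatter) lies within the scatter. Compound 4 `Cc1cccc2sc(NC(=O)CCN3CCN(c4ncccn4)CC3)nc12` differs from compound 3 by pyrimidin-2-yl in place of pyridin-2-yl on an amine nitrogen in a ring. Within the data shown here, no measured step covers this change; the sole step seen, pyridin-2-yl replacing 2-(dimethylamino)ethyl, stayed within the scatter, so no step beyond the scatter is expected in this assay. Compound 4 is therefore estimated at 1400 nM, between 500 nM and 4000 nM, which is an expected step of no change at the digits printed from compound 3 to compound 4 (within the scatter).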

Compound 4, half-maximal inhibitory concentration: 1330 nM
Beside the measured number, compound 4's estimate is 1.1-fold (0.02 log units) above it; the measured number falls inside the stated range.
By their numbers in this assay, from the lowest: compounds 4, 3 and 2 (each within the scatter of the next).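

At this amine nitrogen in a ring, in this assay, pyrimidin-2-yl in place of pyridin-2-yl adds one ring hetero atom and one hydrogen-bond acceptor and gives a 1.1-fold lower number from compound 3 to compound 4 (0.02 log units; within the scatter). Pyrimidin-2-yl in place of 2-(dimethylamino)ethyl gives a 1.6-fold lower number from compound 2 to compound 4 (0.21 log units; within the scatter), so the three groups with numbers here all remain within the scatter of one another. No measurement at hand explains this result. The compounds shown leave open whether a phenyl ring, a carboxylic acid or a longer chain on this amine nitrogen would move the number beyond the scatter.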